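Mirror-image pair on the adenosine receptor series

A few compounds are considered here, and "the series" means these few. Any claim that something is new, unique, unknown or untested is made for them only; others in the source may bear on it.

Compound 1 `COc1cccc(-c2nc(N)c3c(C)c(C)n([C@H](C)c4ccccc4)c3n2)c1` gives 83 nM in an assay for binding affinity to adenosine receptor A1 (Rattus norvegicus), read by radioligand binding; a higher number here means a weaker inhibitor, a lower number a stronger inhibitor.
Compound 2 `Cc1c(C)n([C@H](C)c2ccccc2)c2ncnc(N[C@H](C)c3ccccc3)c12` gives 2650 nM in this assay.

Of the two compounds with numbers, compound 2 stands highest in this assay; its nearest neighbour is compound 1, whose value lies well beyond the scatter on the lower side. Compound 3 `Cc1c(C)n([C@@H](C)c2ccccc2)c2ncnc(N[C@@H](C)c3ccccc3)c12` has not yet been measured. Set against compound 2, the account of the change is this: the two compounds have the same atoms and bonds and differ only in configuration as drawn: 2 of 2 stereo elements differ (all stereocentres are inverted: mirror images); a stereocentre at a saturated chain carbon is drawn R in compound 2 and S in compound 3; a stereocentre at a saturated chain carbon is drawn R in compound 2 and S in compound 3. Nothing leaves and nothing enters; compound 3 is simply the mirror image of compound 2 as drawn.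

Within the data shown here, no measured step exists here between two compounds that differ in one place, so the effect of inverting both stereocentres cannot be read from a precedent. A mirror image may bind as well, better or worse than its partner, and the two numbers available give no lever to tell which. Compound 3 is therefore expected to land near compound 2, with a step of a 1.1-fold higher number from compound 2 to compound 3 (0.05 log units; within the scatter) that could fall on either side, and a wide allowance on both ends. The estimate for compound 3 in this assay is 3000 nM, between 500 nM and 15000 nM.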

Compound 3, inhibition constant: 2530 nM
For compound 3 the middle estimate is 1.2-fold (0.07 log units) above the measured one; low and high end bracket the measured number.
By their numbers in this assay, from the lowest: compound 1; then compounds 3 and 2 (each within the scatter of the next).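

Inverting both stereocentres together gives the first step in this series that can be read in this assay (a 1.0-fold lower number from compound 2 to compound 3 (0.02 log units; within the scatter)). The two mirror images are therefore not told apart by this read-out, a result that compounds 1 and 2 alone, which do not differ in one place only, could not give. This is a direct reading of configuration at these two saturated chain carbons, since nothing else in the structures varies: the fact that compounds 2 and 3 differ only in the configuration as drawn

Both stereocentres change at once in this pair, so the data leave open whether inverting only one of them would also give a number within the scatter, or whether two separate effects happen to offset each other in the mirror image. Also open, as far as these compounds go, is how a plain benzyl group, which has no stereocentre at that carbon, would compare with compound 2 and compound 3 if it replaced the chain on the ring nitrogen or the one on the amine.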